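Replacing the 6-(thiophen-2-yl)pyridin-3-yl group of compound 2

The compounds below may be only part of what the source reports. "The series", "measured", "known", "first", "only" and "open" are said of these compounds alone.

Measured so far in a functional assay on G-361 cells (Homo sapiens) for inhibition, with a stated time of 72 h; on this read-out higher numbers stand for weaker inhibition and lower numbers for stronger inhibition:
- compound 1 `NC1CCC(Nc2nc(NCc3ccc(-c4ccco4)nc3)c3ncn(C4CCCC4)c3n2)CC1` gives 97 nM
- compound 2 `NC1CCC(Nc2nc(NCc3ccc(-c4cccs4)nc3)c3ncn(C4CCCC4)c3n2)CC1` gives 150 nM

Within the data shown here, only one measured step is available, a 1.5-fold higher number from compound 1 to compound 2 (0.19 log units; within the scatter), with thiophen-2-yl in place of furan-2-yl on an aromatic carbon. Among the measured compounds shown here, compound 2 therefore stands within the scatter of compound 1 , the only other number to hand.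

Compound 3 `NC1CCC(Nc2nc(NCc3cc(Cl)ccc3O)c3ncn(C4CCCC4)c3n2)CC1` has no number yet. It carries 5-chloro-2-hydroxyphenyl in place of 6-(thiophen-2-yl)pyridin-3-yl on a saturated chain carbon bound to a nitrogen on an aromatic ring, and the count of the change reads 5-chloro-2-hydroxyphenyl in place of 6-(thiophen-2-yl)pyridin-3-yl on a saturated chain carbon bound to a nitrogen on an aromatic ring in full.

For the measured compounds named here, the single measured step bears on this only weakly. Going by the values given here, it exchanged just the outer ring of the group that now leaves, and no measured compound shows the whole group replaced. The expectation is thus a loose one, with a rise in the number thought more likely than a fall. The expected size is a 2.0-fold higher number from compound 2 to compound 3 (0.30 log units; within the scatter) in this assay, and this estimate is uncertain. For compound 3 the estimated value is 300 nM, with an expected range from 60 nM to 1500 nM in this read-out.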

Compound 3, half-maximal inhibitory concentration: 390 nM
For compound 3 the middle estimate is 1.3-fold (0.11 log units) below the measured one, within the range that was stated.
By their numbers in this assay, from the lowest: compounds 1 and 2 (each within the scatter of the next); then compound 3.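

In this assay, the exchange of the whole group on the saturated chain carbon bound to a nitrogen on an aromatic ring moves the number beyond the scatter, unlike the earlier exchange of the outer ring alone. Putting 5-chloro-2-hydroxyphenyl in place of 6-(thiophen-2-yl)pyridin-3-yl brings a 2.6-fold higher number from compound 2 to compound 3 (0.41 log units; beyond the scatter), and putting it in place of 6-(furan-2-yl)pyridin-3-yl brings a 4.0-fold higher number from compound 1 to compound 3 (0.60 log units; beyond the scatter), so both steps run the same way and both are modest in size. No evidence at hand accounts for this rise.

The change swaps the two aromatic rings for a single carbon-only ring and adds the chlorine and the hydroxyl at once, so the compounds shown do not tell these parts apart. Open, too, is how the number would stand at this place with an unsubstituted pyridin-3-yl, which lacks the outer ring, or with a 2-hydroxyphenyl, which lacks the chlorine.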